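The source may report more compounds than this note shows. Statements on the series, on what has been measured and on what is new or still open speak of the compounds shown alone.

Of the compounds shown here, three that share one core have been tested in a functional assay on MCF7 cells (Homo sapiens) for inhibition; on this read-out lower numbers stand for stronger inhibition and higher numbers for weaker inhibition. Compound 1 `COc1c(C)cnc(CN2c3nc(N)nc(Cl)c3NC(=O)[C@H]2C)c1C` gives 790 nM. Compound 3 `COc1c(C)cnc(CN2c3nc(N)nc(Cl)c3NC(=O)[C@@H]2C(C)C)c1C` gives 1600 nM. Compound 2 `COc1c(C)cnc(CN2CC(=O)N(C(C)C)c3c(Cl)nc(N)nc32)c1C` gives 50 nM, the lowest of the three numbers; its gaps to compound 1 and to compound 3 both lie beyond the scatter, so compound 2 is the strongest inhibitor among the compounds measured.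

Compound 4 `COc1c(C)cnc(CN2CC(=O)N(C3CCCC3)c3c(Cl)nc(N)nc32)c1C` has not yet been measured. It differs from compound 2 in one place: cyclopentyl in place of isopropyl on an amide-type nitrogen in a ring. For the measured compounds named here, no pair of measured compounds shows the effect of swapping one such group for another on this amide-type nitrogen in a ring, so the expectation rests on compound 2 alone. The step from compound 2 to compound 4 is expected to be small, with the number for compound 4 staying close to that of compound 2 or moving slightly lower: a 1.3-fold lower number from compound 2 to compound 4 (0.10 log units; within the scatter). In this assay compound 4 is therefore estimated at 40 nM, within a range from 12 nM to 130 nM.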

Compound 4, half-maximal inhibitory concentration: 820 nM
Compound 4: middle estimate off by 21-fold (1.31 log units), on the low side, outside the stated range (above it).
By their numbers in this assay, from the lowest: compound 2; then compounds 1, 4 and 3 (each within the scatter of the next, the first and the last beyond it).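

In this assay, putting cyclopentyl in place of isopropyl on the amide-type nitrogen in a ring gives a 16-fold higher number from compound 2 to compound 4 (1.21 log units; beyond the scatter) and so counts as a large step. For the compounds shown here, this is the first pair of measured compounds that isolates this position, and it shows that the read-out depends strongly on the group placed here, even though both groups contain only carbon, with no hydrogen-bond donors or acceptors and no net charge. Nothing available explains why the number rises so far.

As far as these compounds go, whether the ring itself or simply the larger number of carbon atoms matters stays open. An open chain such as n-pentyl, or a smaller ring such as cyclopropyl, on this nitrogen would help to separate the two.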